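A Second Methoxy on Compound 2

The source may report more compounds than this note shows. Statements on the series, on what has been measured and on what is new or still open speak of the compounds shown alone.

In a functional assay on HCT-116 cells (Homo sapiens) for cytotoxicity, read by MTT assay, with a stated time of 72 h (a higher number here means a weaker inhibitor, a lower number a stronger inhibitor), compound 1 `Cc1cc(/C=C/c2ccc(O)cc2)[nH]n1` gives 38800 nM as its reading, compound 2 `COc1ccc(/C=C/c2cc(C)n[nH]2)cc1` gives 9400 nM and compound 3 `COc1cc(/C=C/c2cc(C)[nH]n2)ccc1O` gives 78800 nM on the same scale. Compound 2 therefore has the lowest number of the three. Compound 4 `COc1ccc(/C=C/c2cc(C)n[nH]2)cc1OC` differs from compound 2 in one place: methoxy in place of hydrogen on an aromatic carbon, a methoxy in place of hydrogen on an aromatic carbon, ortho to a methoxy group. Among the measured compounds shown here, one measured step bears on this, a 4.1-fold lower number from compound 1 to compound 2 (0.62 log units; beyond the scatter), seen with methyl in place of hydrogen on an oxygen on an aromatic ring. That step concerns a different kind of change, so it offers only indirect guidance. A closer hint is that compound 3 carries a methoxy that compound 1 lacks, and compound 3 reads 78800 nM where compound 1 reads 38800 nM in the same test series. A small move toward a higher number is therefore expected, and the estimated step is a 1.7-fold higher number from compound 2 to compound 4 (0.23 log units; within the scatter), though that estimate is loose. For compound 4 the estimated value is 16000 nM, with an expected range from 6000 nM to 45000 nM as its likely span.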

Compound 4, half-maximal inhibitory concentration: 51300 nM
Estimate against measurement, compound 4: 3.2-fold (0.51 log units) below, and the stated range ends below it.
By their numbers in this assay, from the lowest: compound 2; then compounds 1, 4 and 3 (each within the scatter of the next, the first and the last beyond it).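

In this assay the added methoxy, ortho to a methoxy group, gives a 5.5-fold higher number from compound 2 to compound 4 (0.74 log units; beyond the scatter) and so shows that this ring carbon is sensitive to substitution, at least when a methoxy group is already present. The result also qualifies an earlier step: a 4.1-fold lower number from compound 1 to compound 2 (0.62 log units; beyond the scatter) came with methyl in place of hydrogen on an oxygen, yet compound 3 at 78800 nM and compound 4 at 51300 nM differ by that same change and lie within the scatter of each other. Nothing available explains why the number rises with this added group.

From the compounds shown here alone, it remains open whether this rise is specific to methoxy or would also appear with a smaller or larger group on this carbon, such as a fluorine atom or an ethoxy group. It is also unknown whether the same methoxy would have a similar effect without the existing methoxy group.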